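Swapping an Aryl Amine for Piperidine on a Quinone Core

A few compounds are considered here, and "the series" means these few. Any claim that something is new, unique, unknown or untested is made for them only; others in the source may bear on it.

Of the compounds shown here, two sharing a fused four-ring core have been tested in a functional assay on ECa-109 cells for inhibition, with ECa-109 cell line (Homo sapiens) as the target, read by sulforhodamine B assay; a higher number here means a weaker inhibitor, a lower number a stronger inhibitor. Compound 1 `O=C1C=C(Nc2ccc(I)cc2)C(=O)c2c1nc1n2[C@H]2OC[C@@H](O)[C@H]2OC1` carries a (4-iodophenyl)amino group on a double-bonded ring carbon and gives 2300 nM. Compound 2 `CCOc1ccccc1NC1=CC(=O)c2c(nc3n2[C@H]2OC[C@@H](O)[C@H]2OC3)C1=O` instead carries a (2-ethoxyphenyl)amino group and gives 4320 nM. Compound 1 has the lower of the two numbers, but the gap to compound 2 lies within the scatter of this kind of measurement, so the two cannot be told apart.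

Compound 3 `O=C1C=C(N2CCCCC2)C(=O)c2c1nc1n2[C@H]2OC[C@@H](O)[C@H]2OC1` is the next compound to be measured in this assay. Its change from compound 1 is piperidin-1-yl in place of (4-iodophenyl)amino on a double-bonded ring carbon. The aromatic ring and the hydrogen-bond donor are gone, and a saturated ring with a single nitrogen takes their place. Among the measured compounds shown here, with no measured pair of this kind to lean on, the expectation is a modest move toward a higher number, somewhat beyond the scatter, as the step of a 2.4-fold higher number from compound 1 to compound 3 (0.38 log units; beyond the scatter) is expected to show. Compound 3 is therefore expected to give about 5500 nM, within a range from 1500 nM to 20000 nM.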

Compound 3, half-maximal inhibitory concentration: > 8000 nM
Compound 3: a limit, no number; the forecaster's own chance of this, stated with the estimate: 10%; middle value at least 1.4-fold (0.16 log units) from the limit.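

In this assay compound 3 gives > 8000 nM, which is a limit of the assay and not a number: the limit of > 8000 nM in this assay, at which 1 of the 3 values shown sits.

Placing piperidin-1-yl instead of (4-iodophenyl)amino on this double-bonded ring carbon gives an at least 3.4-fold higher number from compound 1 to compound 3 (0.54 log units; beyond the scatter), so the group at this place can shift the reading by more than the scatter, which the two aryl amino groups of compound 1 and compound 2 did not show. The change removes the aromatic ring and the hydrogen-bond donor in a single step, so this one comparison cannot say which of the two losses matters, or whether both do.

The compounds shown leave that question open: a cyclohexylamino group would keep the amine hydrogen on a saturated ring, while an N-methyl-N-phenylamino group would keep the aromatic ring without that hydrogen. They also leave open whether a different saturated ring, such as morpholin-4-yl, would behave like piperidin-1-yl at this place.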